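Neopentyl in place of phenyl: expectation for compound 3

A few compounds are considered here, and "the series" means these few. Any claim that something is new, unique, unknown or untested is made for them only; others in the source may bear on it.

In a functional assay on a cell-free system (plasma, Homo sapiens), with a stated time of 3 min (on this read-out higher numbers stand for weaker inhibition and lower numbers for stronger inhibition), compound 2 (`O=C(NCc1cc(Cl)ccc1-n1cnnn1)[C@@H]1[C@H]2C[C@H]2CN1C(=O)[C@H](O)c1ccccc1`) gives 960 nM and compound 1 (`CC(C)(C)[C@@H](O)C(=O)N1C[C@@H]2C[C@@H]2[C@H]1C(=O)NCc1cc(Cl)ccc1-n1cnnn1`) gives 570 nM, so the two values lie within the scatter of each other. Compound 3 (`CC(C)(C)C[C@@H](O)C(=O)N1C[C@@H]2C[C@@H]2[C@H]1C(=O)NCc1cc(Cl)ccc1-n1cnnn1`) has neopentyl in place of phenyl on a saturated chain carbon bound to a carbonyl carbon and an oxygen on a saturated carbon. Within the data shown here, the only measured step at this place is a 1.7-fold higher number from compound 1 to compound 2 (0.23 log units; within the scatter), with phenyl in place of tert-butyl. Among the measured compounds shown here, no neopentyl compound has been measured yet. The expected step in this assay is a 1.6-fold lower number from compound 2 to compound 3 (0.20 log units; within the scatter), no larger than the scatter. The estimate for compound 3 is 600 nM, with a range of 200 nM to 1800 nM.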

Compound 3, half-maximal inhibitory concentration: 910 nM
The estimate for compound 3 lay 1.5-fold (0.18 log units) below the measured number; the measured number falls inside the stated range.
By their numbers in this assay, from the lowest: compounds 1, 3 and 2 (each within the scatter of the next).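

In this assay, the step to neopentyl on a saturated chain carbon bound to a carbonyl carbon and an oxygen on a saturated carbon is a 1.1-fold lower number from compound 2 to compound 3 (0.02 log units; within the scatter) and, against tert-butyl, a 1.6-fold higher number from compound 1 to compound 3 (0.20 log units; within the scatter). Neopentyl, which has no ring, thus takes the place of phenyl, with its six-membered aromatic ring, without a step beyond the scatter, and phenyl, tert-butyl and neopentyl are not separated on this read-out. Nothing on hand explains this result.

On these data alone, whether an amine or a carboxylic acid at this place would give a step beyond the scatter remains open.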